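The source may report more compounds than this note shows. Statements on the series, on what has been measured and on what is new or still open speak of the compounds shown alone.

Measured in a functional assay on KB cells (nasopharynx, Homo sapiens) for antiproliferative activity; a higher number here means a weaker inhibitor, a lower number a stronger inhibitor:
- compound 1 `Cc1ccc(S(=O)(=O)Nc2cccc3cc[nH]c23)cc1`: 2.2 ug/mL
- compound 2 `O=S(=O)(Nc1cccc2cc[nH]c12)c1ccc(Cl)cc1`: 6 ug/mL
- compound 3 `N#Cc1ccc(S(=O)(=O)Nc2cccc3cc[nH]c23)cc1`: 8.5 ug/mL

Compound 3 sits at the weak end of this small set. There is a 3.9-fold higher number from compound 1 to compound 3 (0.59 log units; beyond the scatter), but a 1.4-fold higher number from compound 2 to compound 3 (0.15 log units; within the scatter), so compound 2 and compound 3 cannot be told apart.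

The next structure, compound 4 `Nc1ccc(S(=O)(=O)Nc2cccc3cc[nH]c23)cc1`, carries amino in place of cyano on an aromatic carbon.

Among the measured compounds shown here, no measured step involves amino, so the evidence is indirect. The three compounds differ only at this same place, and the steps there are small. There is a 2.7-fold higher number from compound 1 to compound 2 (0.44 log units; beyond the scatter), and the step to compound 3 is of similar size. Swapping this group has therefore shifted this assay only modestly so far. Compound 3 also has little room to rise compared with compound 1, which has the lowest number at 2.2 ug/mL. A modest step towards lower numbers is therefore expected, though with real uncertainty.

The estimate means a 2.4-fold lower number from compound 3 to compound 4 (0.39 log units; beyond the scatter). For compound 4 the expected value is 3.5 ug/mL, with an estimated range from 1 ug/mL to 12 ug/mL.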

Compound 4, half-maximal inhibitory concentration: 36 ug/mL
The estimate for compound 4 lay 10-fold (1.01 log units) below the measured number; measured number above the stated range.
By their numbers in this assay, from the lowest: compound 1; then compounds 2 and 3 (each within the scatter of the next); then compound 4.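

In this assay the swaps among methyl, chloro and cyano on this aromatic carbon, para to a large group, stayed modest, but amino gives a clearly larger shift: a 4.2-fold higher number from compound 3 to compound 4 (0.63 log units; beyond the scatter) and a 6.0-fold higher number from compound 2 to compound 4 (0.78 log units; beyond the scatter) stand with a 16-fold higher number from compound 1 to compound 4 (1.21 log units; beyond the scatter) as the steps to it. This position is therefore more sensitive to the choice of group than the first three compounds could show, and amino is the poorest of the four groups here. Nothing available explains why amino behaves so differently from the other three groups.

The compounds shown leave open whether a dimethylamino group or an acetamide at this place would track amino or the other three groups. They also leave open where a hydroxyl group or a methoxy group would fall.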